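The source may report more compounds than this note shows. Statements on the series, on what has been measured and on what is new or still open speak of the compounds shown alone.

Measured compounds:
compound 1, `CCOC(=O)c1cnc(CC)nc1NN1C(=O)C=C(C)C1=O`, 10000 nM
compound 2, `CCOC(=O)c1cnc(-c2csc(C)n2)nc1NN1C(=O)C=C(C)C1=O`, 8000 nM
compound 3, `CCOC(=O)c1cnc(-c2ccc(Cl)cc2)nc1NN1C(=O)C=C(C)C1=O`, 300 nM

Of the compounds shown here, three sharing one core have been tested in a functional assay on Jurkat cells for inhibition of nuclear factor NF-kappa-B complex (Homo sapiens); a higher number here means a weaker inhibitor, a lower number a stronger inhibitor. Compound 1 carries an ethyl group on the core and gives 10000 nM. In this assay compound 2, with a 2-methyl-1,3-thiazol-4-yl group in place of the ethyl, gives 8000 nM; the step of a 1.3-fold lower number from compound 1 to compound 2 (0.10 log units; within the scatter) lies within the scatter. Compound 3, with a 4-chlorophenyl group, gives 300 nM and has the lowest number of the three: the steps of a 33-fold lower number from compound 1 to compound 3 (1.52 log units; beyond the scatter) and a 27-fold lower number from compound 2 to compound 3 (1.43 log units; beyond the scatter) are both large.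

Compound 4, `CCOC(=O)c1cnc(-c2ccsc2)nc1NN1C(=O)C=C(C)C1=O`, has not yet been measured. It differs from compound 3 by thiophen-3-yl in place of 4-chlorophenyl on an aromatic carbon. Going by the values given here, two measured steps bear on this change: both replacements of a five-membered or open-chain group by the 4-chlorophenyl group gave large gains, and the five-membered 2-methyl-1,3-thiazol-4-yl group in compound 2 gave a number close to that of the ethyl in compound 1. Since the thiophen-3-yl group is again a five-membered ring, the author expects the step of a 10-fold higher number from compound 3 to compound 4 (1.00 log units; beyond the scatter) to run upward, beyond the scatter, though perhaps less far than the step from compound 2 to compound 3. In this assay compound 4 is therefore estimated at 3000 nM, with a likely range from 800 nM to 12000 nM.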

Compound 4, half-maximal inhibitory concentration: 100 nM
The estimate for compound 4 lay 30-fold (1.48 log units) above the measured number, outside the stated range (below it).
By their numbers in this assay, from the lowest: compound 4; then compound 3; then compounds 2 and 1 (each within the scatter of the next).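

In this assay, the position between two ring nitrogen atoms does not depend on the 4-chlorophenyl group: thiophen-3-yl, with fewer heavy atoms and no chlorine, goes further still, giving a 3.0-fold lower number from compound 3 to compound 4 (0.48 log units; beyond the scatter), a modest step that nevertheless lies beyond the scatter. A five-membered aromatic ring at this position therefore does not by itself keep the number high, as the two five-membered groups are separated by an 80-fold lower number from compound 2 to compound 4 (1.90 log units; beyond the scatter), and thiophen-3-yl also gives the largest gain over the ethyl group, a 100-fold lower number from compound 1 to compound 4 (2.00 log units; beyond the scatter), making compound 4 the strongest inhibitor of the four. No measurement shown here explains why these groups differ so widely.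

The compounds shown leave open whether an unsubstituted phenyl group, a pyridine ring or a furan-3-yl group would give a number as low, and whether the gap between compound 2 and compound 4 follows the methyl group or the ring nitrogen of the 2-methyl-1,3-thiazol-4-yl group, since the two differ together. They also leave open whether the low number survives replacing the ethoxycarbonyl group with a carboxylic acid or an amide.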